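The compounds below may be only part of what the source reports. "The series", "measured", "known", "first", "only" and "open" are said of these compounds alone.

Two compounds share one core and differ only in the aryl group that sits on a carbonyl carbon. Compound 1 `COc1cccc(C(=O)c2ccc3c(ccn3S(=O)(=O)c3cccc(/C=C/C(=O)NO)c3)c2)c1` carries a 3-methoxyphenyl there; in an assay on isolated protein for inhibition of protein deacetylase HDAC6 (Homo sapiens) (on this read-out higher numbers stand for weaker inhibition and lower numbers for stronger inhibition), compound 1 gives 1810 nM. Compound 2 `COc1cc(C(=O)c2ccc3c(ccn3S(=O)(=O)c3cccc(/C=C/C(=O)NO)c3)c2)cc(OC)c1OC` carries a 3,4,5-trimethoxyphenyl in that place, and in this assay compound 2 gives 562 nM. Going by the values given here, the single measured step, a 3.2-fold lower number from compound 1 to compound 2 (0.51 log units; beyond the scatter), lies beyond the scatter, so compound 2 stands with the lower of the two numbers and thus the stronger inhibition.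

Compound 3 `Cc1ccc(C(=O)c2ccc3c(ccn3S(=O)(=O)c3cccc(/C=C/C(=O)NO)c3)c2)cc1` moves in the opposite direction: 4-methylphenyl in place of 3,4,5-trimethoxyphenyl on a carbonyl carbon. Where adding two methoxy groups lowered the number in the measured step, here all three leave and a plain methyl on the ring arrives, with no hydrogen-bond acceptors at all. Among the compounds with values here, only that one step bears on the question, and it was modest in size. Compound 3 is therefore expected to show a step of a 2.8-fold higher number from compound 2 to compound 3 (0.45 log units; beyond the scatter), back towards, and perhaps beyond, where compound 1 stands. The estimate for compound 3 in this assay is 1600 nM, within a range from 500 nM to 5000 nM.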

Compound 3, half-maximal inhibitory concentration: 2750 nM
Beside the measured number, compound 3's estimate is 1.7-fold (0.24 log units) below it, and the stated range covers the measured number.
By their numbers in this assay, from the lowest: compound 2; then compounds 1 and 3 (each within the scatter of the next).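

In this assay, the change to 4-methylphenyl on the carbonyl carbon brings a 4.9-fold higher number from compound 2 to compound 3 (0.69 log units; beyond the scatter), so compound 2 now stands apart from a second neighbour and not only from compound 1. The new comparison gives a 1.5-fold higher number from compound 1 to compound 3 (0.18 log units; within the scatter), which lies within the scatter, so 3-methoxyphenyl and 4-methylphenyl cannot be told apart at this position, and among these three aryl groups only 3,4,5-trimethoxyphenyl gives a clearly different number. No information is available that would explain why this aryl group stands apart.

Going by these compounds alone, whether the lower number of compound 2 depends on all three methoxy groups stays open, as compound 2 is the only compound here with several on the ring. Equally open, on these data alone, is how a plain phenyl, or a ring carrying an amine or a carboxylic acid, would read at this position.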